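Mirror-image inversion of a trihydroxylated pipecolic acid

The compounds below may be only part of what the source reports. "The series", "measured", "known", "first", "only" and "open" are said of these compounds alone.

Measured so far:
- compound 1, `O=C(O)[C@H]1NCC=C[C@@H]1O`: 60% in an assay on isolated protein for inhibition of cytosolic endo-beta-N-acetylglucosaminidase (Homo sapiens), tested at 1000 uM; on this read-out lower numbers stand for less inhibition and higher numbers for more inhibition at the one concentration tested (going by the name of the read-out)
- compound 2, `O=C(O)[C@H]1NC[C@H](O)[C@H](O)[C@H]1O`: 7.6%
- compound 3, `O=C(O)[C@@H]1NC[C@@H](O)[C@H](O)[C@@H]1O`: 0.8%

Compound 2 stands second highest of the three numbers. Its nearest neighbour is compound 3, reached by a number 6.8 percentage points lower from compound 2 to compound 3 (within the scatter), a step that lies within the scatter; its furthest is compound 1, which sits beyond the scatter above it. For the measured compounds named here, the step from compound 2 to compound 3 inverts three of the four stereocentres, and this is the only change between them, because of the fact that compounds 2 and 3 differ only in the configuration as drawn.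

Compound 4, `O=C(O)[C@@H]1NC[C@@H](O)[C@@H](O)[C@@H]1O`, is not yet measured. Compared with compound 2 it changes as follows: the two compounds have the same atoms and bonds and differ only in configuration as drawn: 4 of 4 stereo elements differ (all stereocentres are inverted: mirror images); a stereocentre at a saturated ring carbon is drawn S in compound 2 and R in compound 4; a stereocentre at a saturated ring carbon is drawn S in compound 2 and R in compound 4; a stereocentre at a saturated ring carbon is drawn S in compound 2 and R in compound 4; a stereocentre at a saturated ring carbon is drawn S in compound 2 and R in compound 4. Going by the values given here, only the step from compound 2 to compound 3 bears on this: a change of configuration alone, which moved the number by a number 6.8 percentage points lower from compound 2 to compound 3 (within the scatter), within the scatter. Turning all four centres at once is therefore expected to give at most a small shift, likely downward, and no step beyond the scatter is expected: a number 3.6 percentage points lower from compound 2 to compound 4 (within the scatter). Compound 4 is expected to give 4%, with a range from 0% to 15%.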

Compound 4, a percentage reported as inhibition, at one concentration (the size of the read-out at that concentration, not a potency): 2.1%
For compound 4 the middle estimate is 1.9 percentage points above the measured one, and the stated range covers the measured number.
By their numbers in this assay, from the lowest: compounds 3, 4 and 2 (each within the scatter of the next); then compound 1.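

In this assay the full mirror-image inversion gives a number 5.5 percentage points lower from compound 2 to compound 4 (within the scatter) and so adds a case in which all four stereocentres turn at once, not only three. For the compounds shown here, the inversion of a single stereocentre gives a number 1.3 percentage points higher from compound 3 to compound 4 (within the scatter) and isolates one centre, which the earlier compounds could not do. Among these three trihydroxylated compounds, no configuration shown, the exact mirror image included, separates from the others beyond the scatter at this one concentration.

From the compounds shown here alone, whether inverting stereocentres would matter on the core of compound 1, which gives 60% in this assay, stays open. So does the effect on the trihydroxylated compounds of an amide or a methyl ester in place of the carboxylic acid, or of a longer chain on the nitrogen.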